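This account rests on a few compounds, and the source may have more. Where it says the series, first, only, none or still open, it means among the compounds named here.

In a functional assay on the whole organism for inhibition, with Mus musculus as the target, at a dose of 32 mg/kg by the oral route (on this read-out higher numbers stand for more inhibition at the one dose given (going by the name of the read-out) and lower numbers for less inhibition), compound 2 `CN(C(=O)c1c(O)c2cc(Sc3ccccc3)ccc2n(C)c1=O)c1ccccc1` gives 100%. Compound 1 `CCSc1ccc2c(c1)c(O)c(C(=O)N(C)c1ccccc1)c(=O)n2C` gives 100% in this assay, and the step of no change at the digits printed from compound 1 to compound 2 (within the scatter) stays within the scatter. Within the data shown here, compound 3 `CSc1ccc2c(c1)c(O)c(S(=O)(=O)N(C)c1ccccc1)c(=O)n2C` gives 53%, so compound 2 stands level with compound 1 and well above compound 3; compound 3 differs from both in more than one place, so no single step connects it to them. Compound 4 `CN(C(=O)c1c(O)c2cc([S+](C)[O-])ccc2n(C)c1=O)c1ccccc1` differs from compound 2 in one place: a group of 3 heavy atoms (1 carbon, 1 oxygen, 1 sulfur; no ring) in place of a group of 7 heavy atoms (6 carbon, 1 sulfur; one six-membered aromatic ring of carbon only), on an aromatic carbon. Among the measured compounds shown here, no measured step exchanges a sulfur-bound phenyl for this entering group; the only step that alters the group on that sulfur, no change at the digits printed from compound 1 to compound 2 (within the scatter), was within the scatter. Compound 4 is therefore expected to show the step of a number 25 percentage points lower from compound 2 to compound 4 (beyond the scatter). Compound 4 is estimated at 75%, between 35% and 100%.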

Compound 4, a percentage reported as inhibition, in the whole organism at one dose (the size of the read-out at that dose, not a potency): 100%
For compound 4 the middle estimate is 25 percentage points below the measured one; the range from low to high includes it.
By their numbers in this assay, from the lowest: compound 3; then compounds 1, 2 and 4 (each within the scatter of the next).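

In this assay, the sulfur-bound group on this aromatic carbon was changed further than before: replacing phenylsulfanyl with the group of one carbon, one oxygen and one sulfur gives no change at the digits printed from compound 2 to compound 4 (within the scatter), and replacing the ethyl-bearing sulfur group with that same group gives no change at the digits printed from compound 1 to compound 4 (within the scatter). So a sulfur substituent bearing oxygen fits here as well as the two plain sulfur-linked groups, at least at this single dose. From the compounds shown here alone, whether an amine or a carboxylic acid on this carbon would keep the read-out remains open. Nothing available explains why such different groups give the same result.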